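Bromo to methoxy across two cores

The source may hold more compounds than are shown below. What is called first, only, known or untested is meant among the compounds shown, and "the series" means these compounds.

Compound 1 `CCCNNC(=O)c1ccc(CNC(=O)c2cc3cc(Br)ccc3[nH]2)cc1` and compound 2 `CCCNNC(=O)c1ccc(CNC(=O)c2cc3cc(OC)ccc3[nH]2)cc1` share one core. In a functional assay on MV4-11 cells (Homo sapiens) for antiproliferative activity, with a stated time of 48 h (on this read-out higher numbers stand for weaker inhibition and lower numbers for stronger inhibition), compound 1 gives 66.5 nM and compound 2 gives 37.5 nM. The change between them is methoxy in place of bromo on an aromatic carbon, and it made a 1.8-fold lower number from compound 1 to compound 2 (0.25 log units; within the scatter). Compound 3 `CCCNNC(=O)c1ccc(CNC(=O)c2cc3cc(Br)ccc3o2)cc1` carries a different core; how its core differs from the core of compound 1 is not broken down here. In this assay compound 3 gives 159 nM, the highest of the three numbers, beyond the scatter from both compound 1 and compound 2. Compound 4 `CCCNNC(=O)c1ccc(CNC(=O)c2cc3cc(OC)ccc3o2)cc1` is not yet measured; it differs from compound 3 by methoxy in place of bromo on an aromatic carbon, the same change seen between compound 1 and compound 2, now made on the core of compound 3. Because a 1.8-fold lower number from compound 1 to compound 2 (0.25 log units; within the scatter) stayed within the scatter, the step in this assay is expected to be of similar size, a 1.8-fold lower number from compound 3 to compound 4 (0.25 log units; within the scatter). Compound 4 is estimated at 90 nM, between 45 nM and 180 nM.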

Compound 4, half-maximal inhibitory concentration: 52.1 nM
Beside the measured number, compound 4's estimate is 1.7-fold (0.24 log units) above it, and the stated range covers the measured number.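

Methoxy in place of bromo on the core of compound 3 gives a 3.1-fold lower number from compound 3 to compound 4 (0.48 log units; beyond the scatter) in this assay on this read-out. The change points the same way on both cores, and the size of the step carries over from the core of compound 1 to the core of compound 3 with no difference beyond the scatter: the same change on two cores in this assay, a 1.8-fold lower number (0.25 log units; within the scatter) from compound 1 to compound 2 and a 3.1-fold lower number (0.48 log units; beyond the scatter) from compound 3 to compound 4, 1.7-fold (0.24 log units) apart, within the scatter of two such steps
This rests on two cores and one pair of groups, so it does not show that the step would hold on other cores or explain why it has this size.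

Still open, going by these compounds, is how ethoxy, hydroxy or an amine would read at this aromatic carbon on either core. On these data alone, a carboxylic acid there is equally open.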